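Benzyl Ester of a Proline Acid in the Tail Flick Test

This account rests on a few compounds, and the source may have more. Where it says the series, first, only, none or still open, it means among the compounds named here.

Compound 1 `O=C(O)[C@@H]1CCCN1C(=O)CN(c1nc(Cl)nc2[nH]cnc12)C1CC1` gives 31.5% in a functional assay on the whole organism (Tail, strain ICR) with Mus musculus as the target, in the tail flick test, with a stated time of 30 min, at a dose of 25 umol/kg by the oral route (a higher number here means a stronger effect of the compound at the dose given, a lower number a weaker effect), the highest of the three numbers recorded. Compound 2 `O=C(CN(c1ncnc2c1ncn2C1CCCCO1)C1CC1)N[C@@H](CO)C(=O)OCc1ccccc1` gives 27.8% in this assay, and compound 3 `N=C(N)NCCC[C@H](NC(=O)CN(c1nc(Cl)nc2[nH]cnc12)C1CC1)C(=O)OCc1ccccc1` gives 23.2%, both within the usual scatter of compound 1, so no order among the three can be claimed. Compound 4 `O=C(OCc1ccccc1)[C@@H]1CCCN1C(=O)CN(c1nc(Cl)nc2[nH]cnc12)C1CC1` has not yet been measured. It differs from compound 1 by benzyl in place of hydrogen on an oxygen next to a carbonyl group. Compounds 2 and 3, which both carry a benzyl ester, give numbers within the scatter of compound 1, so the step from compound 1 to compound 4 is expected to be small, a number 3.5 percentage points lower from compound 1 to compound 4 (within the scatter), and not beyond the scatter. Compound 4 is therefore estimated at 28%, within a range of 15% to 40%.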

Compound 4, a percentage reported as activity, at one dose (the size of the read-out at that dose, not a potency): 33.2%
Estimate against measurement, compound 4: 5.2 percentage points below, within the range that was stated.
By their numbers in this assay, from the lowest: compounds 3, 2, 1 and 4 (each within the scatter of the next).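

In this assay, among the compounds shown here, the pair gives the first direct reading of this position, as no earlier pair differed in one place: benzyl in place of hydrogen on an oxygen next to a carbonyl group gives a number 1.7 percentage points higher from compound 1 to compound 4 (within the scatter). At this dose, carboxy and benzyloxycarbonyl therefore cannot be told apart. Nothing available bears on why the two read alike.

Going by these compounds, whether a methyl ester or a primary amide at this place would also read alike stays open. So does whether the pair stays alike at other doses or times.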